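This account rests on a few compounds, and the source may have more. Where it says the series, first, only, none or still open, it means among the compounds named here.

Of the compounds shown here, three have been tested so far in an ADME assay on HEK293 cells (Homo sapiens) for cytotoxicity, read by reporter gene assay and resazurin assay, with a stated time of 48 h; on this read-out higher numbers stand for lower toxicity in this test and lower numbers for higher toxicity in this test. Compound 1 `COc1c(Br)cccc1C(=O)Nc1ccccc1` gives > 100000 nM, which is a limit of the assay and not a number. Compound 2 `O=C(Nc1ccc(Sc2nc3ccccc3s2)cc1)c1ccccc1`, the starting point of this story, gives > 100000 nM, and this too is only a limit. Compound 3 `O=C(Nc1ccc(Sc2nc3ccccc3s2)c(Cl)c1)c1cccc(Br)c1` gives > 100000 nM, again a limit. The set as a whole shows (the limit of > 100000 nM in this assay, at which 3 of the 3 values shown sit). Compound 2 therefore cannot be placed in any order against the other two, and it offers no exact number to start from.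

The next compound, compound 4 `O=C(Nc1ccc(Sc2nc3ccccc3s2)cc1)c1cc(Br)cc(Br)c1O`, keeps the rest of compound 2 and changes a single group, with 3,5-dibromo-2-hydroxyphenyl in place of phenyl on a carbonyl carbon. Among the compounds with values here, no measured pair shows what a change of this kind does, so any forecast here is a judgement. A move toward lower numbers in this assay, meaning higher toxicity, is expected, and it should be larger than the usual scatter, although compound 4 could also remain at the limit. The expected size of this move is an at least 3.3-fold lower number from compound 2 to compound 4 (0.52 log units; beyond the scatter). For compound 4 the estimated value is 30000 nM, with an expected range from 5000 nM to 100000 nM.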

Compound 4, half-maximal cytotoxic concentration: 66000 nM
Compound 4: middle estimate off by 2.2-fold (0.34 log units), on the low side; the range from low to high includes it.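

On the carbonyl carbon, putting 3,5-dibromo-2-hydroxyphenyl in place of phenyl gives the first sign that this spot can shift the result in this assay, with an at least 1.5-fold lower number from compound 2 to compound 4 (0.18 log units; that floor lies within the scatter). Within the data shown here, compound 2 stands at > 100000 nM, which is a limit of the assay and not a number, so the printed step is only a floor: the true gap could be larger, but the values alone secure no more than a step within the usual scatter. Compound 4, at 66000 nM, is the only compound so far with an exact number and so the first that can serve as a reference for later comparisons, while the rest remain at: the limit of > 100000 nM in this assay, at which 3 of the 4 values shown sit.

The change brings in the hydroxy group and the two bromines together, so the compounds shown cannot tell which of them accounts for the lower number. From the compounds shown here alone, it also stays open how this ring would read with the hydroxy group alone, with the bromines alone, or with an amine or a carboxylic acid in place of the hydroxy group.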